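This account rests on a few compounds, and the source may have more. Where it says the series, first, only, none or still open, it means among the compounds named here.

In a functional assay on A549 cells (Homo sapiens) for inhibition, read by sulforhodamine B assay, with a stated time of 48 h (a higher number here means a weaker inhibitor, a lower number a stronger inhibitor), compound 1 (`O=C(Nc1ccc2c(c1)N(Cc1ccc(C(=O)NO)cc1)CC2)Nc1ccc(Cl)c(C(F)(F)F)c1`) gives 2800 nM and compound 2 (`O=C(Nc1ccc(C(=O)NO)cc1)Nc1ccc(Cl)c(C(F)(F)F)c1`) gives 7200 nM as measured numbers. Compound 3 (`O=C(Nc1ccc(Nc2ncc(C(=O)NO)cn2)cc1)Nc1ccc(Cl)c(C(F)(F)F)c1`) reads > 10000 nM in this assay as a limit and not a number, so it sits at the limit of the assay.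

Compound 4 (`O=C(CCCCCC(=O)Nc1ccc(NC(=O)Nc2ccc(Cl)c(C(F)(F)F)c2)cc1)NO`) carries (5-(hydroxycarbamoyl)pentyl)carbonyl in place of 5-(hydroxycarbamoyl)pyrimidin-2-yl on a nitrogen on an aromatic ring. The six-membered aromatic ring with 2 hetero atoms leaves, and no ring enters.

Among the compounds with values here, no measured pair isolates this change, so the size of the step in this assay rests on expectation alone. Within the data shown here, the only numbers to lean on are compound 1 at 2800 nM and compound 2 at 7200 nM in the same assay, and compound 4 is expected to fall near them. The expected change is an at least 3.3-fold lower number from compound 3 to compound 4 (0.52 log units; beyond the scatter) in the direction of a stronger inhibitor. Compound 4 is estimated at 3000 nM with an expected range from 900 nM to 10000 nM as the likely outcome.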

Compound 4, half-maximal inhibitory concentration: > 10000 nM
Compound 4 gave a limit, no number; the forecaster's own chance of this, stated with the estimate: 10%; middle value at least 3.3-fold (0.52 log units) away from the limit.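

Compound 3 and compound 4 both read as limits and not numbers, so no step can be read between them: the limit of > 10000 nM in this assay, at which 2 of the 4 values shown sit.

How far apart the 5-(hydroxycarbamoyl)pyrimidin-2-yl and (5-(hydroxycarbamoyl)pentyl)carbonyl groups lie in this assay stays open with the compounds shown.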